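Swapping Methyl for Fluoro on a Hydroxamic Acid Series

The source may report more compounds than this note shows. Statements on the series, on what has been measured and on what is new or still open speak of the compounds shown alone.

Measured so far:
- Compound 1, `Cc1ccc(-n2nc(-c3ccccc3)nc2CNc2ccc(C(=O)NO)cc2)cc1`, gives 60.7%.
- Compound 2, `O=C(NO)c1ccc(NCc2nc(-c3cccnc3)nn2-c2ccccc2)cc1`, gives 57.7%.
- Compound 3, `COc1ccc(-n2nc(-c3ccc(O)cc3)nc2CNc2ccc(C(=O)NO)cc2)cc1`, gives 70.3%.

All three numbers come from an assay on Sf9 cells for inhibition of protein deacetylase HDAC6 (Homo sapiens), read by fluorescence, with a stated time of 40 min, tested at 100 nM; a lower number here means less inhibition, a higher number more inhibition at the concentration tested (going by the name of the read-out). Compound 1 holds the second highest of the three values. Its nearest neighbour is compound 2, whose value lies a few points lower, and the furthest is compound 3, whose value lies higher; both gaps sit within the usual scatter of this assay, so the three measured compounds cannot be told apart on these numbers alone, and no ordering among them is claimed.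

The next compound, compound 4, `O=C(NO)c1ccc(NCc2nc(-c3ccccc3)nn2-c2ccc(F)cc2)cc1`, keeps the whole of compound 1 except for one change: fluoro in place of methyl on an aromatic carbon. Put one bond further out, the 4-methylphenyl of compound 1 becomes a 4-fluorophenyl in compound 4. Both groups are single heavy atoms with no donors or acceptors, so the shape of the rest of the molecule is untouched.

Among the measured compounds shown here, no pair of measured compounds differs in exactly this way, so there is no direct precedent for the size of this step. Given that the three measured compounds all fall within the scatter of one another despite larger changes, the step from compound 1 to compound 4 is expected to be small and in no clear direction, at most around the scatter. Compound 4 is therefore estimated at 60%, with an expected range from 45% to 75%, meaning an expected change of a number 0.7 percentage points lower from compound 1 to compound 4 (within the scatter).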

Compound 4, a percentage reported as inhibition, at one concentration (the size of the read-out at that concentration, not a potency): 67.6%
Compound 4: middle estimate off by 7.6 percentage points, on the low side, within the range that was stated.
By their numbers in this assay, from the lowest: compounds 2, 1, 4 and 3 (each within the scatter of the next, the first and the last beyond it).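

In this assay, putting fluoro in place of methyl on an aromatic carbon, para to a large group, gives a number 6.9 percentage points higher from compound 1 to compound 4 (within the scatter), and this step lies within the usual scatter. Among the compounds shown here, this is the first comparison in the set in which only one place differs, so it isolates this position in a way the earlier compounds could not, and on this read-out, taken at a single concentration, the 4-methylphenyl and 4-fluorophenyl compounds cannot be told apart. Nothing at hand bears on what lies behind this result.

The compounds shown leave open whether any group at this position would produce a step beyond the scatter, since methyl and fluoro are both single heavy atoms with no hydrogen-bond donors or acceptors, and an amine, a carboxylic acid or a longer chain such as propyl would test the position far more severely. They also leave open how the two groups compare as true potencies, as a percentage at one concentration does not give a potency.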